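Shortening the Hydroxamate Linker in a Glioma Cell Assay

The compounds below may be only part of what the source reports. "The series", "measured", "known", "first", "only" and "open" are said of these compounds alone.

Compound 1 `C#CCN(C)CCCOc1cc(NC(=O)CCCCCCCC(=O)NO)ccc1Cl` gives 4780 nM in a functional assay on U-251 cells (Homo sapiens) for inhibition, read by MTT assay, with a stated time of 48 h (a lower number here means a stronger inhibitor, a higher number a weaker inhibitor), the lower of the two numbers recorded; compound 2 `C#CCN(C)CCCOc1cc(NCc2ccc(C(=O)NO)cc2)ccc1Cl` gives 7120 nM in this assay, a difference the two values show to lie within the scatter. Compound 3 `C#CCN(C)CCCOc1cc(NC(=O)CCCCCCC(=O)NO)ccc1Cl` is not yet measured. It differs from compound 1 by hydroxycarbamoyl in place of (hydroxycarbamoyl)methyl on a saturated chain carbon, six bonds along the chain from a carbonyl carbon. For the measured compounds named here, with no measured step of this kind available, only a small move is expected, if any, toward a lower number. Compound 3 is therefore estimated at 3000 nM, between 1200 nM and 9000 nM, a step of a 1.6-fold lower number from compound 1 to compound 3 (0.20 log units; within the scatter).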

Compound 3, half-maximal inhibitory concentration: 600 nM
The estimate for compound 3 lay 5.0-fold (0.70 log units) above the measured number, outside the stated range (below it).
By their numbers in this assay, from the lowest: compound 3; then compounds 1 and 2 (each within the scatter of the next).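

In this assay, the change from (hydroxycarbamoyl)methyl to hydroxycarbamoyl gives an 8.0-fold lower number from compound 1 to compound 3 (0.90 log units; beyond the scatter), so this chain position responds to a small change in length: 5 heavy atoms leave, 4 enter, and the hydroxycarbamoyl end stays. For the compounds shown here, the step is the first measured at this position, and it lies beyond the scatter. Nothing available explains why the shorter chain gives the lower number. Going by these compounds, whether a still shorter chain would continue this direction remains open, as does whether a carboxylic acid could replace the hydroxycarbamoyl end.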